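Lengthening the Chain in a Chlorophenoxy-Linked Series

This account rests on a few compounds, and the source may have more. Where it says the series, first, only, none or still open, it means among the compounds named here.

Measured so far:
compound 1, `N#C/N=C1\N(CCCCCCOc2ccc(Cl)cc2)C(=O)CN1c1ccncc1`: 3440 nM
compound 2, `CC1C(=O)N(CCCCCCOc2ccc(Cl)cc2)/C(=N\C#N)N1c1ccncc1`: 333 nM
compound 3, `N#C/N=C1\N(CCCCCOc2ccc(Cl)cc2)C(=O)CCN1c1ccncc1`: 6740 nM

In a functional assay on DLD-1 cells (Homo sapiens) for cytotoxicity (on this read-out lower numbers stand for stronger inhibition and higher numbers for weaker inhibition), compound 3 gives the highest of the three numbers; its nearest neighbour is compound 1, whose value lies within the scatter, while compound 2 is far lower. Compound 4, `N#C/N=C1\N(CCCCCCOc2ccc(Cl)cc2)C(=O)CCN1c1ccncc1`, is the unmeasured compound. It differs from compound 3 by (4-chlorophenoxy)methyl in place of 4-chlorophenoxy on a saturated chain carbon, five bonds along the chain from an amide-type nitrogen in a ring; in plain terms, the chain linking the shared core to the 4-chlorophenoxy group grows by one carbon.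

For the measured compounds named here, the single measured step, a 10-fold lower number from compound 1 to compound 2 (1.01 log units; beyond the scatter), concerns a methyl on the core and so says nothing about chain length. Compound 1 and compound 3 differ in more than one place, and their two values sit within the scatter of each other, so chain length has not yet shown any clear effect. The expectation for a 1.3-fold lower number from compound 3 to compound 4 (0.13 log units; within the scatter) is therefore a step no larger than the scatter, in either direction. Compound 4 is estimated at 5000 nM, with a range from 1500 nM to 15000 nM.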

Compound 4, half-maximal inhibitory concentration: 565 nM
Compound 4: the middle estimate sits 8.8-fold (0.95 log units) above what was measured, outside the stated range (below it).
By their numbers in this assay, from the lowest: compounds 2 and 4 (each within the scatter of the next); then compounds 1 and 3 (each within the scatter of the next).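

Adding one carbon to the chain, with (4-chlorophenoxy)methyl in place of 4-chlorophenoxy, gives a 12-fold lower number from compound 3 to compound 4 (1.08 log units; beyond the scatter) in this assay and so belongs among the large steps on this read-out. Chain length, which had shown no clear effect among the earlier compounds, therefore matters at this position, and a change as small as one carbon is enough to move the number beyond the scatter. Why this one carbon has such an effect remains unexplained, as nothing at hand bears on the cause.

On these data alone, whether a still longer chain would lower the number further or raise it again remains open, as does whether the same step would appear on the core of compound 2. It is also unknown how a chain ending in an amine, in place of the 4-chlorophenoxy group, would behave.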